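Swapping Nitro for Fluoro on Two Related Cores

The source may hold more compounds than are shown below. What is called first, only, known or untested is meant among the compounds shown, and "the series" means these compounds.

Four compounds are considered here, three of them measured in an ADME assay on J774 cells (Mus musculus) for cytotoxicity, read by fluorescence and resazurin assay, with a stated time of 24 h; on this read-out higher numbers stand for lower toxicity in this test and lower numbers for higher toxicity in this test. Compound 1 `O=[N+]([O-])c1ccc(S(=O)(=O)Nc2ccc3nccnc3c2)cc1` carries a nitro group. In this assay compound 1 gives only a limit, >= 300000 nM, a value that (the limit of >= 300000 nM in this assay, at which 1 of the 3 values shown sits). Compound 2 `O=S(=O)(Nc1ccc2nccnc2c1)c1ccc(F)cc1` differs from compound 1 in a single place: fluoro in place of nitro on an aromatic carbon. In this assay compound 2 gives 43900 nM, so the change produced an at least 6.8-fold lower number from compound 1 to compound 2 (0.83 log units; beyond the scatter).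

Compound 3 `O=[N+]([O-])c1ccc(S(=O)(=O)Nc2ccc3[nH]ncc3c2)cc1` keeps the nitro group but is built on a different core; how the core of compound 3 differs from the core of compound 1 is not broken down here. In this assay compound 3 gives 133000 nM, the higher of the two numbers reported, with compound 2 its nearest measured neighbour.

Compound 4 `O=S(=O)(Nc1ccc2[nH]ncc2c1)c1ccc(F)cc1` has not yet been measured. It differs from compound 3 in one place: fluoro in place of nitro on an aromatic carbon. The place of the change is the same as between compound 1 and compound 2, so it is the same change made on the other core.

The expectation can rest only on that one measured instance. Beside an at least 6.8-fold lower number from compound 1 to compound 2 (0.83 log units; beyond the scatter), the step in this assay is expected to be a 5.3-fold lower number from compound 3 to compound 4 (0.73 log units; beyond the scatter), because an at least 6.8-fold lower number from compound 1 to compound 2 (0.83 log units; beyond the scatter) is known only as a bound and the move on a different core may fall shorter. Compound 4 is accordingly estimated at 25000 nM, expected to lie between 8000 nM and 80000 nM.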

Compound 4, half-maximal cytotoxic concentration: >= 300000 nM
Compound 4: no number, only a limit; the forecaster's own chance of this, stated with the estimate: 5%; middle value at least 12-fold (1.07 log units) away from the limit.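

In this assay compound 4 gives >= 300000 nM, which is a limit of the assay and not a number. Fluoro in place of nitro on an aromatic carbon thus gives an at least 2.2-fold higher number from compound 3 to compound 4 (0.35 log units; beyond the scatter), so in this series the change does not carry from one core to the other in either direction or size: the same change on two cores in this assay, an at least 6.8-fold lower number (0.83 log units; beyond the scatter) from compound 1 to compound 2 and an at least 2.2-fold higher number (0.35 log units; beyond the scatter) from compound 3 to compound 4, at least 15-fold (1.18 log units) apart, beyond the scatter of two such steps. Within the data shown here, this does not show why the two cores part ways, and with only one pair on each core it sets no rule for any other core, while each step has a limit at one end and so gives only a bound: the limit of >= 300000 nM in this assay, at which 2 of the 4 values shown sit.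

The compounds shown leave open how an amine, a carboxylic acid or a nitrile in place of the nitro group would read on either core, and so whether fluoro is a special case or one of several groups that split the two cores. They also leave open whether, on a third core, the same change would follow the step seen on the core of compound 1 or the one seen on the core of compound 3.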